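This account rests on a few compounds, and the source may have more. Where it says the series, first, only, none or still open, it means among the compounds named here.

The measured compounds in an ADME assay on L6 cells (Rattus norvegicus) for cytotoxicity, read by resazurin assay, with a stated time of 70 h; on this read-out lower numbers stand for stronger inhibition and higher numbers for weaker inhibition:

Compound 1, `COc1cc(NC(C)CCCNC(=O)N(C2CCCCC2)C2CCCCC2)c2ncccc2c1` — compound 1 gives "not determined" (no result reported).
Compound 2, `COc1cc(NC(C)CCCNC(=O)NNC(=O)/C(C)=C/c2ccccc2)c2ncccc2c1` — compound 2 gives 36500 nM.
Compound 3, `COc1cc(NC(C)CCCNC(=O)NNC(=O)/C=C/c2ccc(OC)c(OC)c2)c2ncccc2c1` — compound 3 gives 37000 nM.

For the measured compounds named here, compound 3 stands at the higher of the two reported numbers, but its only neighbour with a value, compound 2, sits within the usual scatter of it, so the two cannot be told apart in this assay. Compound 1 carries no result and gives no point of comparison.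

Compound 4 is `COc1cc(NC(C)CCCNC(=O)NNC(=O)/C=C/c2ccccc2F)c2ncccc2c1`. It differs from compound 3 in one place: 2-fluorophenyl in place of 3,4-dimethoxyphenyl on a double-bonded chain carbon bound to a double-bonded chain carbon. The same difference, cut one bond further out, reads 2-(3,4-dimethoxyphenyl)ethenyl to 2-(2-fluorophenyl)ethenyl.

Going by the values given here, one measured step bears on this region of the molecule. It is a 1.0-fold higher number from compound 2 to compound 3 (0.01 log units; within the scatter), a change on the same side chain, which left the number essentially where it was. Among the compounds with values here, with only this step to go on, the expectation for compound 4 is a shift of no more than the scatter, in no particular direction, estimated as no change at the digits printed from compound 3 to compound 4 (within the scatter).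

Compound 4 is therefore expected to give about 37000 nM in this assay, with a likely range from 18000 nM to 75000 nM.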

Compound 4, half-maximal inhibitory concentration: 25100 nM
Estimate against measurement, compound 4: 1.5-fold (0.17 log units) above, and the stated range covers the measured number.
By their numbers in this assay, from the lowest: compounds 4, 2 and 3 (each within the scatter of the next).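

In this assay, putting 2-fluorophenyl in place of 3,4-dimethoxyphenyl on a double-bonded chain carbon bound to a double-bonded chain carbon gives a 1.5-fold lower number from compound 3 to compound 4 (0.17 log units; within the scatter) and so stays inside the normal spread of repeated measurements. The earlier step changed only the substituents around a phenyl-bearing ethenyl chain, whereas this one removes both methoxy groups, going from 10 heavy atoms and 2 hydrogen-bond acceptors in the leaving group to 7 heavy atoms and 0 acceptors in the entering one, and brings in fluorine, yet the reading can still not be told apart; the comparison with the methyl-bearing chain, a 1.5-fold lower number from compound 2 to compound 4 (0.16 log units; within the scatter), agrees with this. No measurement shown here offers an explanation for this flat result.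

As far as these compounds go, all three compounds with numbers carry a plain or lightly substituted phenyl ring on an ethenyl chain, so it remains open whether an amine or a carboxylic acid on that ring, or a longer chain in place of the ethenyl link, would move the number beyond the scatter. From the compounds shown here alone, with no result for compound 1, the effect of replacing the whole side chain with its two cyclohexyl groups also stays unknown.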